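From acetyl to carbamoyl: what three close values suggest

The source may report more compounds than this note shows. Statements on the series, on what has been measured and on what is new or still open speak of the compounds shown alone.

In a functional assay (aorta) with Oryctolagus cuniculus as the target (on this read-out higher numbers stand for weaker binding and lower numbers for tighter binding), compound 1 `COc1cc(C(C)=O)ccc1OCCCN1CCC(C(c2ccc(F)cc2)c2ccc(F)cc2)CC1` gives 1.59 nM while compound 2 `COc1cc(OCCCN2CCC(C(c3ccc(F)cc3)c3ccc(F)cc3)CC2)ccc1C(C)=O` gives 3.16 nM and compound 3 `CC(=O)c1ccc(OCCCN2CCC(C(c3ccc(F)cc3)c3ccc(F)cc3)CC2)cc1` gives 2.51 nM so compound 3 lies within the scatter of both others. Compound 4 `NC(=O)c1ccc(OCCCN2CCC(C(c3ccc(F)cc3)c3ccc(F)cc3)CC2)cc1` keeps the shared core and alters one group amino in place of methyl on a carbonyl carbon (amino in place of methyl on a carbonyl carbon, so 4-acetylphenyl becomes 4-carbamoylphenyl). Within the data shown here, no measured step makes this exact change, so the evidence is indirect. Putting hydrogen in place of methoxy on an aromatic carbon gave a 1.6-fold higher number from compound 1 to compound 3 (0.20 log units; within the scatter) and also a 1.3-fold lower number from compound 2 to compound 3 (0.10 log units; within the scatter) while moving the methoxy group gave a 2.0-fold higher number from compound 1 to compound 2 (0.30 log units; within the scatter) and none of these steps leaves the scatter. Across these three compounds, then, small edits left the number in this assay essentially unchanged, although the carbonyl group itself was never altered. The expected result is a 1.3-fold higher number from compound 3 to compound 4 (0.11 log units; within the scatter) which means no step beyond the scatter and no firm direction. For compound 4 the estimated value is 3.2 nM with an expected range from 1 nM to 10 nM as a deliberately wide margin for an untested change.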

Compound 4, dissociation constant: 31.6 nM
Compound 4: middle estimate off by 9.9-fold (0.99 log units), on the low side; the whole stated range lies below it.
By their numbers in this assay, from the lowest: compounds 1, 3 and 2 (each within the scatter of the next); then compound 4.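

In this assay, among these compounds, the carbonyl carbon proves far less forgiving than the methoxy edits: amino in place of methyl, which turns acetyl into carbamoyl and brings in a hydrogen-bond donor, gives a 13-fold higher number from compound 3 to compound 4 (1.10 log units; beyond the scatter) and so leaves the scatter that held all the earlier steps. The methoxy-bearing compounds show a gap of the same kind, with a 10-fold higher number from compound 2 to compound 4 (1.00 log units; beyond the scatter) and a 20-fold higher number from compound 1 to compound 4 (1.30 log units; beyond the scatter) so compound 4 stands apart from all three acetyl compounds. Nothing measured here explains why this swap matters so much.

Still open, going by these compounds, is whether the loss of methyl or the arrival of amino drives the shift. A methylamino group or a hydroxyl on the same carbonyl carbon, the latter giving a carboxylic acid, would help separate the two.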